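Swapping the para group for a meta-bromine on the anilino ring

The source may report more compounds than this note shows. Statements on the series, on what has been measured and on what is new or still open speak of the compounds shown alone.

Three compounds have been measured in a functional assay on A549 cells (Homo sapiens) for antiproliferative activity, read by MTT assay, with a stated time of 72 h; on this read-out higher numbers stand for weaker inhibition and lower numbers for stronger inhibition:

- compound 1, `O=C(C1=C(Nc2ccc(I)cc2)C(=O)N(CCCn2ccnc2)C1c1ccc(Br)cc1)c1ccccc1`, gives 24500 nM
- compound 2, `O=C(C1=C(Nc2ccc(Cl)cc2)C(=O)N(CCCn2ccnc2)C1c1ccc(Br)cc1)c1ccccc1`, gives 30000 nM
- compound 3, `O=C(C1=C(Nc2ccc(OC(F)(F)F)cc2)C(=O)N(CCCn2ccnc2)C1c1ccc(Br)cc1)c1ccccc1`, gives 20800 nM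

All three share one core and differ only in the group on the anilino ring. Compound 3 has the lowest of the three numbers, but the steps of a 1.2-fold lower number from compound 1 to compound 3 (0.07 log units; within the scatter) and a 1.4-fold lower number from compound 2 to compound 3 (0.16 log units; within the scatter) are both small, and the step of a 1.2-fold higher number from compound 1 to compound 2 (0.09 log units; within the scatter) is equally small, so the three are not separated by this assay.

Compound 4, `O=C(C1=C(Nc2cccc(Br)c2)C(=O)N(CCCn2ccnc2)C1c1ccc(Br)cc1)c1ccccc1`, has not been measured. It differs from compound 3 in one place: 3-bromophenyl in place of 4-(trifluoromethoxy)phenyl on an amine nitrogen. Among the compounds with values here, none of the measured steps changes the position of the group on that ring; they only exchange one group for another at the same place, and every such exchange stayed within the scatter. Within the data shown here, there is therefore no measured step that bears directly on this change, and the expectation is that the number will stay close to those already seen, with no step beyond the scatter in either direction, so that the expected step is a 1.2-fold higher number from compound 3 to compound 4 (0.08 log units; within the scatter). Compound 4 is estimated to give 25000 nM in this assay, within a range from 10000 nM to 60000 nM.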

Compound 4, half-maximal inhibitory concentration: 15800 nM
Estimate against measurement, compound 4: 1.6-fold (0.20 log units) above; measured number inside the range.
By their numbers in this assay, from the lowest: compounds 4, 3, 1 and 2 (each within the scatter of the next).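

Replacing 4-(trifluoromethoxy)phenyl with 3-bromophenyl on the amine nitrogen changes both the group and its place on the ring, yet this assay still does not separate the compounds: the printed steps are a 1.3-fold lower number from compound 3 to compound 4 (0.12 log units; within the scatter) and a 1.6-fold lower number from compound 1 to compound 4 (0.19 log units; within the scatter) and a 1.9-fold lower number from compound 2 to compound 4 (0.28 log units; within the scatter). All four compounds therefore remain indistinguishable here, so the wider change at this position gives no measurable gain or loss. Nothing in the available data accounts for the small differences among them.

The compounds shown do not include one group at two places on this ring, so the contribution of place cannot be separated from that of the group. From the compounds shown here alone, it also remains open whether an amine or a carboxylic acid on the anilino ring would shift the number beyond the scatter.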